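Ester to acid on the phenyl of the urea series

The compounds below may be only part of what the source reports. "The series", "measured", "known", "first", "only" and "open" are said of these compounds alone.

Compound 2 `COC(=O)c1cccc(C2(CNC(=O)Nc3c(C(C)C)cccc3C(C)C)CCCC2)c1` gives the higher of the two numbers in an assay on microsomes for inhibition of acyl-CoA:cholesterol acyltransferase (Oryctolagus cuniculus); on this read-out lower numbers stand for stronger inhibition and higher numbers for weaker inhibition: compound 2 gives 34 nM, while compound 1 `COc1cccc(C2(CNC(=O)Nc3c(C(C)C)cccc3C(C)C)CCCC2)c1` gives 13 nM; the step was a 2.6-fold higher number from compound 1 to compound 2 (0.42 log units; beyond the scatter), a methoxycarbonyl in place of methoxy. Compound 3 `CC(C)c1cccc(C(C)C)c1NC(=O)NCC1(c2cccc(C(=O)O)c2)CCCC1` differs from compound 2 by hydrogen in place of methyl on an oxygen next to a carbonyl group. Among the compounds with values here, no measured step covers this change; only the modest methoxy-to-ester step stands nearby, so a modest weakening is expected, a 2.4-fold higher number from compound 2 to compound 3 (0.37 log units; beyond the scatter). Compound 3 is therefore estimated at 80 nM, within 25 nM to 300 nM.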

Compound 3, half-maximal inhibitory concentration: 620 nM
Estimate against measurement, compound 3: 7.8-fold (0.89 log units) below; the measured number lies above the stated range.
By their numbers in this assay, from the lowest: compound 1; then compound 2; then compound 3.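

In this assay the aromatic carbon carrying these groups proved far less forgiving of the carboxy group than of the methoxycarbonyl group: hydrogen in place of methyl on the ester oxygen gives an 18-fold higher number from compound 2 to compound 3 (1.26 log units; beyond the scatter) and is no longer a modest change. Measured against the methoxy group, carboxy gives a 48-fold higher number from compound 1 to compound 3 (1.68 log units; beyond the scatter) and is the largest step in this short series. No available evidence bears on the reason for this loss.

Going by these compounds, whether a primary amide or a hydroxymethyl group on this carbon stays close to the ester or falls towards the acid remains open. So does whether a carboxylic acid on a longer chain fares any better.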